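Methoxy to hydrogen in a small aminophenyl series

This account rests on a few compounds, and the source may have more. Where it says the series, first, only, none or still open, it means among the compounds named here.

Values in a functional assay on HeLa cells (Homo sapiens) for inhibition, read by cell counting, with a stated time of 4 days; on this read-out higher numbers stand for weaker inhibition and lower numbers for stronger inhibition:

compound 1 `Nc1cccc(-c2cn3nc(Cc4ccccc4)sc3n2)c1`: 24000 nM
compound 2 `COc1ccc(-c2nn3cc(-c4cccc(N)c4)nc3s2)cc1OC`: 26000 nM
compound 3 `COc1ccc(Cc2nn3cc(-c4cccc(N)c4)nc3s2)cc1`: 191000 nM

Within the data shown here, only one change is repeated in this set. From compound 3 to compound 1 the change is hydrogen in place of methoxy on an aromatic carbon, and the step in this assay is an 8.0-fold lower number from compound 3 to compound 1 (0.90 log units; beyond the scatter). Between compound 2 and compound 3 the cores differ in a way that is not broken down here; the values simply show a higher number for compound 3 than for compound 2. Compound 1 and compound 2 sit within the usual scatter of each other, so no order is read between them.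

Compound 4 `COc1ccc(-c2nn3cc(-c4cccc(N)c4)nc3s2)cc1` has not been measured in this assay. It differs from compound 2 by hydrogen in place of methoxy on an aromatic carbon. The surroundings differ from the earlier pair: in compound 3 the leaving methoxy sits para to a large group, while in compound 2 it sits ortho to a methoxy group and meta to a large group. The change is therefore the same kind of change, not the same change.

Among the measured compounds shown here, the expectation rests on the one measured step. Because an 8.0-fold lower number from compound 3 to compound 1 (0.90 log units; beyond the scatter) lowered the number, a smaller lowering is expected here as well, and the step from compound 2 to compound 4 is estimated at a 1.7-fold lower number from compound 2 to compound 4 (0.24 log units; within the scatter). Compound 4 is expected to give about 15000 nM in this assay, within a range from 5000 nM to 50000 nM.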

Compound 4, half-maximal inhibitory concentration: >= 250000 nM
Compound 4: only a limit was reported; the forecaster's own chance of this, stated with the estimate: 5%; middle value at least 16-fold (1.22 log units) from the limit.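

Compound 4 gives >= 250000 nM in this assay, which is a limit of the assay and not a number. Even with that limit, hydrogen in place of methoxy gives an at least 9.6-fold higher number from compound 2 to compound 4 (0.98 log units; beyond the scatter), the opposite direction to the earlier step, and the change does not carry from one core to the other in this series: the same change on two cores in this assay, an 8.0-fold lower number (0.90 log units; beyond the scatter) from compound 3 to compound 1 and an at least 9.6-fold higher number (0.98 log units; beyond the scatter) from compound 2 to compound 4, at least 76-fold (1.88 log units) apart, beyond the scatter of two such steps

The two pairs differ both in the core and in the surroundings of the leaving methoxy, which in compound 2 sits ortho to a methoxy group and meta to a large group. They therefore do not separate these two differences, and they give no rule for any other core.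

The compounds shown leave open what a hydroxyl or a fluorine in place of the same methoxy would give on either core, and whether either would follow the direction seen from compound 3 to compound 1 or that seen from compound 2 to compound 4. Also open, from the compounds shown here alone, is where compound 4 would stand as an actual number rather than a limit.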